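The compounds below may be only part of what the source reports. "The series", "measured", "known", "first", "only" and "open" are said of these compounds alone.

Compound 1: `CNc1nc(-n2cc(-c3ccccc3)nn2)nc2c1ncn2[C@@H]1O[C@H](CO)[C@@H](O)[C@H]1O` — 14.9 nM
Compound 2: `CNc1nc(-c2cn(Cc3cccc(OC)c3)nn2)nc2c1ncn2[C@@H]1O[C@H](CO)[C@@H](O)[C@H]1O` — 86.1 nM

Of the compounds shown here, two have been measured in an assay on CHO cells for displacement of a labelled ligand from adenosine receptor A3 (Homo sapiens); a higher number here means a weaker inhibitor, a lower number a stronger inhibitor. Compound 1 gives 14.9 nM, the lower of the two numbers, so it is the stronger inhibitor of the pair. Compound 2 gives 86.1 nM, a higher number, and the gap between the two lies beyond the usual scatter of the method. The two compounds differ in more than one place, so no single change can be tied to that gap.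

Compound 3 is `CNc1nc(-n2cc(-c3ccccn3)nn2)nc2c1ncn2[C@@H]1O[C@H](CO)[C@@H](O)[C@H]1O`. Compared with compound 1, the change is pyridin-2-yl in place of phenyl on an aromatic carbon. For the measured compounds named here, no measured pair shows this exact change, so nothing in the data says how large a step it brings. Swapping one six-membered aromatic ring for another of the same size is often a modest change, and the expected step from compound 1 to compound 3 is a 1.7-fold higher number from compound 1 to compound 3 (0.22 log units; within the scatter), a small weakening that may well stay within the scatter. Compound 3 is therefore expected to give about 25 nM in this assay, with a likely range from 8 nM to 80 nM.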

Compound 3, inhibition constant: 10.3 nM
For compound 3 the middle estimate is 2.4-fold (0.39 log units) above the measured one, within the range that was stated.
By their numbers in this assay, from the lowest: compounds 3 and 1 (each within the scatter of the next); then compound 2.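

In this assay, putting pyridin-2-yl in place of phenyl on an aromatic carbon of the five-membered aromatic ring with 3 nitrogen gives a 1.4-fold lower number from compound 1 to compound 3 (0.16 log units; within the scatter) and this step lies within the usual scatter, so the two compounds cannot be told apart here. This is the first pair shown that differs in one place, and so the first direct reading at this position: the entering ring has one nitrogen where the leaving ring has only carbon, and it counts one hydrogen-bond acceptor where the leaving ring counts none, yet no loss of strength can be seen for this one pair. The data on hand offer no explanation for why the number holds when that ring nitrogen enters.

One pair cannot show whether this tolerance extends to other rings, such as pyridin-3-yl, pyridin-4-yl or a saturated cyclohexyl ring, at the same carbon. It also leaves open what a phenyl ring carrying an amine or a carboxylic acid would do there, and compound 2 cannot help, as it differs from the others in more than one place.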